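Solubility notes on a shared-core oxazolidinone series

The source may report more compounds than this note shows. Statements on the series, on what has been measured and on what is new or still open speak of the compounds shown alone.

Measured compounds:
compound 1 `O=C1O[C@@H](CO)CN1c1ccc(-n2cc(-c3ccccn3)cn2)c(F)c1` gives 56400 nM
compound 2 `CN1CCN(C[C@H]2CN(c3ccc(-n4cc(-c5ccccn5)cn4)c(F)c3)C(=O)O2)CC1` gives 1690000 nM
compound 3 `CS(=O)(=O)NC[C@H]1CN(c2ccc(-n3cc(-c4ccccn4)cn3)c(F)c2)C(=O)O1` gives 2300 nM

In a physicochemical assay for solubility, read by HPLC, with a stated time of 24 h (on this read-out lower numbers stand for lower solubility and higher numbers for higher solubility), compound 3 stands lowest of the three numbers; compound 1 sits nearest, compound 2 furthest, and both gaps are beyond the scatter. The step of a 25-fold lower number from compound 1 to compound 3 (1.39 log units; beyond the scatter) and the step of a 730-fold lower number from compound 2 to compound 3 (2.87 log units; beyond the scatter) show how far a change at this chain position has moved this assay within the series; the step of a 30-fold higher number from compound 1 to compound 2 (1.48 log units; beyond the scatter) shows the same position moving the other way.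

Compound 4 `O=C1O[C@@H](CNC(=O)C(F)(F)F)CN1c1ccc(-n2cc(-c3ccccn3)cn2)c(F)c1` is not yet measured. It differs from compound 3 by (trifluoromethyl)carbonyl in place of methylsulfonyl on an amine nitrogen. For the measured compounds named here, no measured step exchanges one acyl-type group for another at this nitrogen, so the measured steps bear only indirectly: they fix how wide the range at this position has been, not where an exchange of this kind falls within it. With the hydrogen-bond donor count unchanged and one acceptor fewer, the expectation is a step of modest size, plausibly inside the scatter, and the direction is not well fixed by the data.

Compound 4 is therefore estimated at 3000 nM, range 800 nM to 12000 nM, which corresponds to an expected step of a 1.3-fold higher number from compound 3 to compound 4 (0.12 log units; within the scatter).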

Compound 4, solubility: 114000 nM
Estimate against measurement, compound 4: 38-fold (1.58 log units) below; measured number above the stated range.
By their numbers in this assay, from the lowest: compound 3; then compound 1; then compound 4; then compound 2.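

Exchanging only the group on the amine nitrogen, with the nitrogen and its saturated chain carbon kept, gives a 50-fold higher number from compound 3 to compound 4 (1.70 log units; beyond the scatter) in this assay and so covers much of the range that earlier took a change of the whole substituent. Compound 4 lies close to the hydroxy compound, with a 2.0-fold higher number from compound 1 to compound 4 (0.31 log units; beyond the scatter) as a modest step, and remains well short of the 4-methylpiperazin-1-yl compound, with a 15-fold lower number from compound 2 to compound 4 (1.17 log units; beyond the scatter) as a large one, so the low number of compound 3 goes with methanesulfonamido in particular and not with a substituted nitrogen on this chain carbon as such. No measured information here accounts for the size of this exchange.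

As far as these compounds go, it remains open whether the higher number of compound 4 follows the trifluoromethyl group, the carbonyl or the loss of the sulfonyl group, and an acetamide or an ethanesulfonamide on the same nitrogen would help separate these. From the compounds shown here alone, it is also open where a primary amine or a carboxylic acid on this chain carbon would fall relative to the four numbers in hand.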